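Swapping the para substituent on a sulfonyl-linked phenyl ring

The source may hold more compounds than are shown below. What is called first, only, known or untested is meant among the compounds shown, and "the series" means these compounds.

Measured so far:
- compound 1 `O=C(/C=C/c1cnc(N2CCN(S(=O)(=O)c3ccc4ccccc4c3)CC2)s1)NO`: 700 nM
- compound 2 `O=C(/C=C/c1cnc(N2CCN(S(=O)(=O)c3ccc(OC(F)(F)F)cc3)CC2)s1)NO`: 6000 nM

Both compounds share a hydroxamic acid and a thiazole joined through a piperazine to a sulfonyl-bearing aromatic group; they differ only in that aromatic group. In a functional assay on MCF7 cells (Homo sapiens) for antiproliferative activity (on this read-out lower numbers stand for stronger inhibition of growth and higher numbers for weaker inhibition of growth), compound 1 gives 700 nM, while compound 2 gives 6000 nM. Compound 2 therefore holds the higher of the two numbers, and its gap to compound 1 lies beyond the usual scatter, so compound 2 is the weaker growth inhibitor of the pair as measured.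

Compound 3 `Cc1ccc(S(=O)(=O)N2CCN(c3ncc(/C=C/C(=O)NO)s3)CC2)cc1` has not yet been measured. It is built from compound 2 by one change: methyl in place of trifluoromethoxy on an aromatic carbon. The larger trifluoromethoxy group is thus replaced by a single-carbon methyl group at the same aromatic position, with nothing else altered.

Among the compounds with values here, no measured pair isolates this particular change, so the size of the step is uncertain. Compound 3 is expected to land in the same general region as compound 2, with a modest shift toward a lower number that may or may not exceed the scatter, giving an estimated step of a 2.0-fold lower number from compound 2 to compound 3 (0.30 log units; within the scatter). On that basis compound 3 is estimated at 3000 nM in this assay, with a plausible range from 800 nM to 12000 nM.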

Compound 3, concentration for 50% growth inhibition: 2000 nM
The estimate for compound 3 lay 1.5-fold (0.18 log units) above the measured number; the measured number falls inside the stated range.
By their numbers in this assay, from the lowest: compound 1; then compound 3; then compound 2.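

In this assay, methyl in place of trifluoromethoxy on this aromatic carbon gives a 3.0-fold lower number from compound 2 to compound 3 (0.48 log units; beyond the scatter), so a change at this one site, with the rest of the molecule held fixed, moves the number beyond the scatter; the earlier pair could show only the effect of exchanging the whole aromatic group. The step with 4-methylphenyl in place of naphthalen-2-yl on the sulfonyl sulfur is a 2.9-fold higher number from compound 1 to compound 3 (0.46 log units; beyond the scatter), so the methyl group improves on trifluoromethoxy but leaves compound 3 short of compound 1, which keeps the lowest number of the three. Nothing available here explains why either step has its size.

On these data alone, with only trifluoromethoxy and methyl to compare at this aromatic carbon, it remains open how an amine, a carboxylic acid or a longer chain such as propyl would behave there. As far as these compounds go, it also remains open whether a substituted naphthalen-2-yl group on the sulfonyl sulfur, for example one carrying a methyl group, would go lower than compound 1.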